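Adding a Second Hydroxy to a Low-Activity Phenylpropyl Ester

A few compounds are considered here, and "the series" means these few. Any claim that something is new, unique, unknown or untested is made for them only; others in the source may bear on it.

Of the compounds shown here, two have been measured in a functional assay on CCRF-CEM cells (Homo sapiens) for inhibition, read by MTT assay, with a stated time of 2 days, tested at 10 uM; on this read-out higher numbers stand for more inhibition at the one concentration tested (going by the name of the read-out) and lower numbers for less inhibition. Compound 1 `COC(=O)c1cc(-n2cc(-c3cc(O)ccc3O)nn2)ccc1O` carries a methyl ester and a 2,5-dihydroxyphenyl group; in this assay compound 1 gives 52%. Compound 2 `O=C(OCCCc1ccccc1)c1cc(-n2cc(-c3cccc(O)c3)nn2)ccc1O` carries instead a phenylpropyl ester and a 3-hydroxyphenyl group, and in this assay compound 2 gives 9%. Compound 2 thus stands at the lower of the two numbers, and the gap to compound 1 lies beyond the usual scatter; since the two compounds differ in two places at once, the gap cannot be assigned to either change alone.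

Compound 3 `O=C(OCCCc1ccccc1)c1cc(-n2cc(-c3cc(O)ccc3O)nn2)ccc1O` keeps the phenylpropyl ester of compound 2 and differs from it in one place: hydroxy in place of hydrogen on an aromatic carbon. This brings compound 3 to the same 2,5-dihydroxyphenyl group found in compound 1. Going by the values given here, with no single-change step measured, a rise is expected but its size is uncertain; the step of a number 21 percentage points higher from compound 2 to compound 3 (beyond the scatter) is the estimate here. Compound 3 is expected to reach 30%, within a range from 5% to 60%.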

Compound 3, a percentage reported as inhibition, at one concentration (the size of the read-out at that concentration, not a potency): 81%
The estimate for compound 3 lay 51 percentage points below the measured number; the measured number lies above the stated range.
By their numbers in this assay, from the lowest: compound 2; then compound 1; then compound 3.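

On the phenylpropyl ester, going from 3-hydroxyphenyl to 2,5-dihydroxyphenyl in this assay gives a number 72 percentage points higher from compound 2 to compound 3 (beyond the scatter), so a single hydroxy on this ring carbon, ortho to a large group and para to a hydroxy group, separates the lowest number in this set from the highest. With the 2,5-dihydroxyphenyl group held fixed, the change from methyl ester to phenylpropyl ester gives a number 29 percentage points higher from compound 1 to compound 3 (beyond the scatter), which shows that the larger ester does not by itself hold the number down. Compound 2 therefore cannot be read as showing that the phenylpropyl ester goes with a lower number.

Why this hydroxy matters so much remains unexplained by any data at hand. On these data alone, it is also open whether a methoxy group or an amine could replace this hydroxy, and whether a longer chain in the ester would raise the number further or lower it.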